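The source may hold more compounds than are shown below. What is called first, only, known or untested is meant among the compounds shown, and "the series" means these compounds.

The study concerns three measured compounds and one that is still to be measured, all judged in an assay for displacement of a labelled ligand from Apoptosis regulator Bcl-2 (Homo sapiens), read by fluorescence polarization, with a stated time of 30 min; a lower number here means a stronger inhibitor, a higher number a weaker inhibitor. Compound 1 `CC(C)Oc1ccc(-c2cc(C(=O)O)nn2-c2ccccc2)cc1` is the simplest of them; in this assay compound 1 gives 7000 nM. Compound 2 `CC(C)COc1ccc(-c2cc(C(=O)O)nn2-c2ccccc2)cc1` differs from it in one place only, (isobutyl in place of isopropyl on an oxygen on an aromatic ring). For compound 2 this assay reports only a limit, > 10000 nM. The step is therefore known only as a floor, an at least 1.4-fold higher number from compound 1 to compound 2 (0.15 log units; that floor lies within the scatter), because the limit of > 10000 nM in this assay, at which 1 of the 3 values shown sits, caps what can be said about it.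

Compound 3 `CC(C)Oc1ccc(C(=O)Nc2c(C(=O)O)nn(-c3ccc(Oc4ccccc4)cc3)c2-c2ccc(OC(C)C)cc2)cc1` is a much larger molecule; in this assay compound 3 gives 140 nM, the lowest of the two numbers shown, and its nearest measured neighbour is compound 1. How the core of compound 3 differs from the core of compound 1 is not broken down here.

Compound 4 `CC(C)COc1ccc(C(=O)Nc2c(C(=O)O)nn(-c3ccc(Oc4ccccc4)cc3)c2-c2ccc(OC(C)C)cc2)cc1` is the not yet measured compound. It stands to compound 3 exactly as compound 2 stands to compound 1: isobutyl in place of isopropyl on an oxygen on an aromatic ring. Since the two place descriptions read the same word for word, this is the same change, now made on the larger core. On the small core the change made the number rise by a step whose floor lies within the usual scatter, so the second instance is expected to move in the same direction but only modestly, a 2.1-fold higher number from compound 3 to compound 4 (0.33 log units; beyond the scatter). Compound 4 is estimated at 300 nM, with a range from 100 nM to 1500 nM.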

Compound 4, inhibition constant: 1400 nM
Estimate against measurement, compound 4: 4.7-fold (0.67 log units) below; the range from low to high includes it.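

Carried to the larger core, isobutyl in place of isopropyl on an oxygen on an aromatic ring gives a 10-fold higher number from compound 3 to compound 4 (1.00 log units; beyond the scatter) in this assay and so clearly weakens the inhibitor there. This does not show whether the change costs more on the larger core than on the small one, and the two pairs give no measure of how much the core matters: the same change on two cores in this assay, an at least 1.4-fold higher number (0.15 log units; that floor lies within the scatter) from compound 1 to compound 2 and a 10-fold higher number (1.00 log units; beyond the scatter) from compound 3 to compound 4; the limit leaves it open whether they differ. The small-core side of that comparison rests on compound 2, whose reading is a limit and not a number: the limit of > 10000 nM in this assay, at which 1 of the 4 values shown sits.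

The compounds shown carry only isopropyl and isobutyl at this oxygen, so it remains open how a longer chain, a cyclopropylmethyl group or a chain ending in an amine would read on the larger core. Also open, on these data alone, is how isobutyl would read in place of the other isopropyl on an oxygen, which compound 3 and compound 4 both carry, and whether the loss seen on the larger core would return on any further core.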